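A few compounds are considered here, and "the series" means these few. Any claim that something is new, unique, unknown or untested is made for them only; others in the source may bear on it.

Two members of the series carry a carboxylic acid on the shared core and differ in the substituent that sits on the imidazole. Compound 1 `CCCCc1cnc(Cc2ccc(-c3ccccc3C(=O)O)cc2)[nH]1` has a butyl chain there, and compound 2 `Cc1cccc(Cc2cnc(CCc3ccc(-c4ccccc4C(=O)O)cc3)[nH]2)c1` a 3-methylbenzyl group, with the link to the core lengthened by one carbon. In an in vitro functional assay on cells for agonist activity at Bombesin receptor subtype-3 (Homo sapiens), read by luminescence and calcium flux (on this read-out lower numbers stand for an effect already at smaller amounts and higher numbers for an effect only at larger amounts of compound), compound 1 gives only a limit, > 10000 nM, and no number. In this assay, within the data shown here, compound 2 gives 4310 nM, the only number that has been obtained so far. The other entry belongs to compound 1 and is a limit: the limit of > 10000 nM in this assay, at which 1 of the 2 values shown sits. Among the measured compounds shown here, no pair of measured compounds differing in one place is available, so no measured step can be given.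

Compound 3 `O=C(O)c1ccccc1-c1ccc(CCc2ncc(Cc3ccc(F)cc3)[nH]2)cc1` is the next compound, not yet measured; it changes compound 2 at one point only: 4-fluorophenyl in place of 3-methylphenyl on a saturated chain carbon bound to an aromatic carbon. The change swaps one six-membered aromatic ring of carbon only for another of the same size, with no donor or acceptor added. For the measured compounds named here, no measured step in this assay speaks to such a swap; the expectation is therefore a step from compound 2 to compound 3 of a 1.2-fold higher number from compound 2 to compound 3 (0.06 log units; within the scatter), within or close to the scatter, in no fixed direction. For compound 3 the estimate in this assay is 5000 nM, within 1500 nM to 15000 nM.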

Compound 3, half-maximal effective concentration: 1600 nM
Compound 3: the middle estimate sits 3.1-fold (0.49 log units) above what was measured; low and high end bracket the measured number.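

In this assay, among these compounds, the place on a saturated chain carbon bound to an aromatic carbon proves sensitive to the aryl group it carries: 4-fluorophenyl in place of 3-methylphenyl gives a 2.7-fold lower number from compound 2 to compound 3 (0.43 log units; beyond the scatter) and is the first measured single-point step. The step is modest but beyond the scatter, so this place does not treat the two groups alike, even though each is one six-membered aromatic ring of carbon only with 7 heavy atoms and 0 hydrogen-bond donors or acceptors. No measured property among the data shown accounts for the step.

The change removes the methyl and adds the fluorine in a single move, so the compounds shown do not separate the contribution of either substituent, and a plain phenyl, or a chlorine or methoxy group on that ring, would be needed to do so. Also open, as far as these compounds go, is whether the carboxylic acid on the shared core can give way to an amide or a tetrazole, and whether a longer chain on the imidazole changes the value at all.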